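Adding a methoxy to compound 2

This account rests on a few compounds, and the source may have more. Where it says the series, first, only, none or still open, it means among the compounds named here.

Compound 1 `COC(=O)c1c(-c2ccc([N+](=O)[O-])cc2)oc2ccccc2c1=O` and compound 2 `O=C(O)c1c(-c2ccc([N+](=O)[O-])cc2)oc2ccccc2c1=O` share one core. In a functional assay on MCF7 cells (Homo sapiens) for cytotoxicity, read by MTT assay, with a stated time of 6 days (a lower number here means that less compound is needed, a higher number that more compound is needed for the effect), compound 1 gives only a limit, > 25 ug/mL. In this assay compound 2 likewise gives only a limit, > 25 ug/mL. The step between them is a step that the two limits leave unreadable from compound 1 to compound 2, so compound 2 stands at the limit of > 25 ug/mL in this assay, at which 2 of the 2 values shown sit, with no number of its own. Compound 3 `COc1ccc2oc(-c3ccc([N+](=O)[O-])cc3)c(C(=O)O)c(=O)c2c1`, not yet measured, differs from compound 2 by methoxy in place of hydrogen on an aromatic carbon. Within the data shown here, no measured step bears on this change, and no direction can be read from the data. Compound 3 is therefore expected at 30 ug/mL, between 8 ug/mL and 100 ug/mL, which means an expected step that the limit leaves unreadable from compound 2 to compound 3, most likely again a limit.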

Compound 3, concentration for half-maximal effect: 15.9 ug/mL
Compound 3: middle estimate off by 1.9-fold (0.28 log units), on the high side, and the stated range covers the measured number.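

Among these compounds, with the methoxy on the aromatic carbon, compound 3 gives the first actual number in this assay, where the earlier compounds gave only limits. The change gives an at least 1.5-fold lower number from compound 2 to compound 3 (0.19 log units; that floor lies within the scatter), and as compound 2 has only a limit, the true step may be larger. The step between compound 1 and compound 2 cannot be read, and most of the series still has no number: the limit of > 25 ug/mL in this assay, at which 2 of the 3 values shown sit.

On these data alone, whether an amine, a hydroxyl or a longer chain at this place would also give a number stays open. So does whether the methoxy would have the same effect on compound 1.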